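Removing a methoxy group from a cinnamic acid ester series

The source may report more compounds than this note shows. Statements on the series, on what has been measured and on what is new or still open speak of the compounds shown alone.

Three esters of a shared pyrazine-type carboxylic acid core bearing a cinnamic acid fragment were measured for their effect on cell viability. In a functional assay on EA.hy 926 cells (Homo sapiens) for cytotoxicity, read by MTT assay, with stated times of 24 h and 12 h (on this read-out higher numbers stand for an effect only at larger amounts of compound and lower numbers for an effect already at smaller amounts), compound 1 `Cc1nc(C)c(C(=O)Oc2ccccc2/C=C/C(=O)O)nc1C` gives 36700 nM. Compound 2 `COc1cc(/C=C/C(=O)O)ccc1OC(=O)c1nc(C)c(C)nc1C` gives 69400 nM in this assay, the highest of the three numbers, and compound 3 `COc1ccc(OC(=O)c2nc(C)c(C)nc2C)c(/C=C/C(=O)O)c1` gives 48600 nM. The difference between compound 2 and compound 3 is a rearrangement of the same atoms joined differently; how the two cores differ is not broken down here.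

Compound 3 and compound 1 differ by hydrogen in place of methoxy on an aromatic carbon, and this change produced a 1.3-fold lower number from compound 3 to compound 1 (0.12 log units; within the scatter). Compound 4 `Cc1nc(C)c(C(=O)Oc2ccc(/C=C/C(=O)O)cc2)nc1C` is the unmeasured analogue of compound 2, differing from it by hydrogen in place of methoxy on an aromatic carbon. This is the same kind of change as that from compound 3 to compound 1, though the place is not identical: in compound 2 the methoxy sits ortho to a large group and meta to the 2-carboxyethenyl group, whereas in compound 3 it is meta to the 2-carboxyethenyl group and para to the large group.

Among the measured compounds shown here, because the only measured example of this change, a 1.3-fold lower number from compound 3 to compound 1 (0.12 log units; within the scatter), stayed within the scatter, compound 4 is expected to show a step of a 1.3-fold lower number from compound 2 to compound 4 (0.12 log units; within the scatter) in this assay. Compound 4 is therefore estimated at 53000 nM, with a plausible range from 26000 nM to 110000 nM.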

Compound 4, half-maximal effective concentration: 38000 nM
Compound 4: the middle estimate sits 1.4-fold (0.14 log units) above what was measured; the measured number falls inside the stated range.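

In this assay, hydrogen in place of methoxy on an aromatic carbon gives a 1.8-fold lower number from compound 2 to compound 4 (0.26 log units; within the scatter), and set beside the earlier step, the two do not differ: the same change on two cores in this assay, a 1.3-fold lower number (0.12 log units; within the scatter) from compound 3 to compound 1 and a 1.8-fold lower number (0.26 log units; within the scatter) from compound 2 to compound 4, 1.4-fold (0.14 log units) apart, within the scatter of two such steps. In these two pairs, then, the change carries from one core to the other without any difference that can be told from the usual scatter, and on neither core does removing the methoxy group give a step beyond that scatter. This does not show that the methoxy group has a fixed contribution that transfers between cores, since two steps that both lie within the scatter cannot establish a real effect of any size, and two pairs on a single read-out say nothing about other cores in the series or about other kinds of measurement.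

The compounds shown carry only methoxy or hydrogen at these places, so it remains open whether a hydroxy group, an amine or a longer alkoxy chain there would give a step beyond the scatter. Also open, from the compounds shown here alone, is whether such a step would then carry between the cores as this one does, and whether an amide in place of the ester link would leave the numbers in this assay unchanged.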